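Fluoro in Place of Amino: Estimating Microsomal Stability

A few compounds are considered here, and "the series" means these few. Any claim that something is new, unique, unknown or untested is made for them only; others in the source may bear on it.

Compound 1 `COC1(c2nnc3c(Oc4cccc(Cl)c4C)cccn23)CCCCCC1`: < 1%
Compound 2 `Cc1c(Cl)cccc1Oc1cccn2c(C34CCC(N)(CC3)CC4)nnc12`: "not determined" (no result reported)

Both compounds were taken to an ADME assay on microsomes from liver (Mus musculus) for metabolic stability, with a stated time of 10 min; a higher number here means that more of the compound is left, a lower number that less of the compound is left. Compound 2 has no number there, and its entry reads "not determined" (no result reported). Going by the values given here, compound 1 supplies the only reading, (the limit of < 1% in this assay, at which 1 of the 2 values shown sits). That reading is a limit of the assay and not a number, so compound 2 cannot be placed relative to it.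

The next compound to be measured is compound 3 `Cc1c(Cl)cccc1Oc1cccn2c(C34CCC(F)(CC3)CC4)nnc12`. The structural change is fluoro in place of amino on a saturated ring carbon, which is fluoro in place of amino on a saturated ring carbon. The shared core and the aryl ether stay as they are.

Among the compounds with values here, no measured step shows what this exchange does, so the expected size of the change in this assay cannot be read from the data. The expectation rests on compound 1 alone, whose reading of < 1% is a limit. Only a small share of compound 3 is expected to remain, with a modest move towards more compound left and a real chance of another limit.

Compound 3 is estimated at 15%, with an expected range from 2% to 50%.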

Compound 3, percent of the compound remaining: 62%
Estimate against measurement, compound 3: 47 percentage points below, outside the stated range (above it).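

In this assay, compound 3, with fluoro on a saturated ring carbon of a six-membered non-aromatic ring of carbon only, part of a fused or bridged system of two rings, gives a reading that is a number, 62%. The reading of compound 1 is a limit of the assay and not a number: the limit of < 1% in this assay, at which 1 of the 3 values shown sits. Replacing the seven-membered ring group on the aromatic carbon with the fluoro-bearing group of two six-membered rings, while the shared core and the aryl ether stay as they are, goes with a number at least 61 percentage points higher from compound 1 to compound 3 (beyond the scatter), so this one exchange on the shared core separates a compound with almost nothing left from one with most of it left.

As far as these compounds go, the step between the amino and fluoro compounds cannot be read, since compound 2 has no result, so the part played by fluoro itself, as distinct from the two-ring group that carries it, remains unknown. Also open, from the compounds shown here alone, is how a hydroxyl, a nitrile or a plain hydrogen on that saturated ring carbon would read in this assay.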